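The source may hold more compounds than are shown below. What is called first, only, known or untested is meant among the compounds shown, and "the series" means these compounds.

In a functional assay on OVCAR-3 cells (Homo sapiens) for antiproliferative activity, read by MTT assay, with a stated time of 24 h (on this read-out lower numbers stand for stronger inhibition and higher numbers for weaker inhibition), compound 1 `Cc1cccc(NNC(=O)c2ccc(NS(=O)(=O)c3cnc(O)nc3O)cc2)c1` gives > 20000 nM as a limit of the assay, not a number. Compound 2 `Cc1ccccc1C(=O)NNC(=O)c1ccc(NS(=O)(=O)c2cnc(O)nc2O)cc1` gives > 20000 nM as a limit too, so it sits at the limit of > 20000 nM in this assay, at which 2 of the 2 values shown sit, and has no exact position. Compound 3 `Cc1ccc(C(=O)NNC(=O)c2ccc(NS(=O)(=O)c3cnc(O)nc3O)cc2)cc1` differs from compound 2 by 4-methylphenyl in place of 2-methylphenyl on a carbonyl carbon with 4-methylphenyl in place of 2-methylphenyl on a carbonyl carbon. For the measured compounds named here, the only measured step is a step that the two limits leave unreadable from compound 1 to compound 2 and gives no size to work from, so no change beyond the scatter is expected in this assay here. The step expected is a step that the limit leaves unreadable from compound 2 to compound 3 on this estimate. Compound 3 is estimated at 25000 nM with an expected range from 10000 nM to 60000 nM in this assay.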

Compound 3, half-maximal inhibitory concentration: > 20000 nM
Compound 3 ended at the assay's limit; the forecaster's own chance of this, stated with the estimate: 80%; the middle value lies beyond the limit too.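

For the compounds shown here, compound 1, compound 2 and compound 3 all end at a limit of the assay rather than a number, so no step among them can be read: the limit of > 20000 nM in this assay, at which 3 of the 3 values shown sit. On these data alone, how strongly any of the three acts, and whether 2-methylphenyl and 4-methylphenyl differ at all, stays open.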